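This account rests on a few compounds, and the source may have more. Where it says the series, first, only, none or still open, it means among the compounds named here.

Going by the values given here, in a functional assay (plasma) for inhibition, with Homo sapiens as the target (a higher number here means a weaker inhibitor, a lower number a stronger inhibitor), compound 1 `Cc1ccc(S(=O)(=O)N[C@H]2CC/C(=N\OCC3CCCCC3)[C@@H]2C/C=C\CCCC(=O)O)cc1` gives 600 nM and stands highest of the two numbers so far, with compound 2 `Cc1ccc(S(=O)(=O)N[C@H]2CC/C(=N\OCc3ccc(C(F)(F)F)cc3)[C@@H]2C/C=C\CCCC(=O)O)cc1` at 180 nM on the lower side. Compound 3 `O=C(O)CCC/C=C\C[C@H]1/C(=N/OCC2CCCCC2)CC[C@@H]1NS(=O)(=O)c1ccc(F)cc1` differs from compound 1 by fluoro in place of methyl on an aromatic carbon in one place: fluoro in place of methyl on an aromatic carbon, para to a large group. Among the compounds with values here, the only measured step, a 3.3-fold lower number from compound 1 to compound 2 (0.52 log units; beyond the scatter) for a different change (4-(trifluoromethyl)phenyl in place of cyclohexyl), was modest and does not cover this swap. No step beyond the scatter is therefore expected in this assay here. The expected change is a 1.2-fold lower number from compound 1 to compound 3 (0.08 log units; within the scatter) in size. Compound 3 is estimated at 500 nM with 200 nM to 1300 nM as the expected span.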

Compound 3, half-maximal inhibitory concentration: 1800 nM
For compound 3 the middle estimate is 3.6-fold (0.56 log units) below the measured one; measured number above the stated range.
By their numbers in this assay, from the lowest: compound 2; then compound 1; then compound 3.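

The swap from 4-methylphenyl to 4-fluorophenyl exchanges one heavy atom for another, with hydrogen-bond donor and acceptor counts and net charge unchanged, yet it moves the number in this assay (a 3.0-fold higher number from compound 1 to compound 3 (0.48 log units; beyond the scatter)). This position therefore responds to a single-atom change, as the cyclohexyl position did in compound 2 with a larger one. Nothing available accounts for this step.

From the compounds shown here alone, whether the shift comes from losing methyl or gaining fluoro remains open, and a hydrogen, chloro or methoxy group here would help separate them. Whether it carries over to the 4-(trifluoromethyl)phenyl series of compound 2 is also unresolved.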